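Halogen identity and placement on the phenolic ring

The compounds below may be only part of what the source reports. "The series", "measured", "known", "first", "only" and "open" are said of these compounds alone.

Measured compounds:
compound 1 `COc1cc(CNC(=S)NCC(COC(=O)C(C)(C)C)Cc2ccc(C)c(C)c2)cc(Cl)c1O` 30.9 nM
compound 2 `COc1cc(CNC(=S)NCC(COC(=O)C(C)(C)C)Cc2ccc(C)c(C)c2)cc(I)c1O` 232 nM

Within the data shown here, compound 2 has the higher of the two numbers recorded in an assay on CHO cells for displacement of a labelled ligand from transient receptor potential cation channel subfamily V member 1 (Rattus norvegicus); a higher number here means a weaker inhibitor, a lower number a stronger inhibitor; the only comparison available is compound 1, and the step of a 7.5-fold higher number from compound 1 to compound 2 (0.88 log units; beyond the scatter) lies beyond the scatter. Compound 3 `COc1cc(CNC(=S)NCC(COC(=O)C(C)(C)C)Cc2ccc(C)c(C)c2)c(Cl)cc1O` has not been measured. It differs from compound 2 by 2-chloro-4-hydroxy-5-methoxyphenyl in place of 4-hydroxy-3-iodo-5-methoxyphenyl on a saturated chain carbon bound to an amide-type nitrogen, so both the halogen and its place on the ring change at once. Among the measured compounds shown here, the one measured step that bears on it is the halogen swap a 7.5-fold higher number from compound 1 to compound 2 (0.88 log units; beyond the scatter), which ran in the opposite direction; no measured step shows what moving the halogen to the position named in compound 3 does. Reversing the halogen swap alone would point to a lower number, but the relocation is unexplored, so the expected step of a 2.6-fold lower number from compound 2 to compound 3 (0.41 log units; beyond the scatter) is taken as a moderate fall with wide uncertainty. Compound 3 is therefore estimated at 90 nM, within 15 nM to 500 nM.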

Compound 3, inhibition constant: 24.2 nM
Compound 3: middle estimate off by 3.7-fold (0.57 log units), on the high side; measured number inside the range.
By their numbers in this assay, from the lowest: compounds 3 and 1 (each within the scatter of the next); then compound 2.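

The new result separates the two changes that compound 3 combines. Between the two chloro isomers, on the saturated chain carbon bound to an amide-type nitrogen, this assay shows a 1.3-fold lower number from compound 1 to compound 3 (0.11 log units; within the scatter), so the 3-chloro-4-hydroxy-5-methoxyphenyl and 2-chloro-4-hydroxy-5-methoxyphenyl groups cannot be told apart here. The full replacement of 4-hydroxy-3-iodo-5-methoxyphenyl gives a 9.6-fold lower number from compound 2 to compound 3 (0.98 log units; beyond the scatter), which shows that, among these three compounds, only the iodo compound stands apart. Nothing shown here accounts for these numbers.

As far as these compounds go, it remains open whether an iodo group would give the same number in the place chloro holds in compound 3. Bromo and fluoro groups in either place, and the effect of a hydrogen in place of the halogen, also remain open.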